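Removing a methyl from the dimethoxy chalcone of compound 2

The compounds below may be only part of what the source reports. "The series", "measured", "known", "first", "only" and "open" are said of these compounds alone.

Compounds measured so far:
- compound 1 `COc1ccc(/C=C/C(=O)c2cccc(-c3cccc(F)c3)c2)cc1` — > 50000 nM
- compound 2 `COc1ccc(/C=C/C(=O)c2cccc(-c3cccc(F)c3)c2)cc1OC` — 33400 nM
- compound 3 `COc1ccc(/C=C/C(=O)c2cccc(-c3ccc(F)cc3)c2)cc1OC` — > 50000 nM

Within the data shown here, in an assay on A549 cells for inhibition of transcription factor p65 (Homo sapiens), read by fluorescence, with a stated time of 2 h (a lower number here means a stronger inhibitor, a higher number a weaker inhibitor), compound 2 gives 33400 nM, the only number among the three results. For compound 1 the result is a limit of the assay, > 50000 nM. For compound 3 the result is likewise a limit, > 50000 nM. Compound 2 therefore stands alone with a measured value, and the limit of > 50000 nM in this assay, at which 2 of the 3 values shown sit, shows how little room the other two leave for comparison.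

Compound 4 `COc1cc(/C=C/C(=O)c2cccc(-c3cccc(F)c3)c2)ccc1O` differs from compound 2 by hydrogen in place of methyl on an oxygen on an aromatic ring. Among the measured compounds shown here, the only measured step touching the same region is an at least 1.4-fold lower number from compound 1 to compound 2 (0.17 log units; that floor lies within the scatter), which shows that adding methoxy at that position gave a gain whose floor lies within the scatter. The other step, an at least 1.4-fold higher number from compound 2 to compound 3 (0.17 log units; that floor lies within the scatter), concerns the fluorophenyl and does not bear on the oxygen. For the measured compounds named here, no measured step speaks to trading methyl for hydrogen on that oxygen, so in this assay a change no larger than the scatter is expected, with a real chance that only a limit is returned.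

Compound 4 is estimated at 40000 nM, within 15000 nM to 100000 nM; this estimate means a step of a 1.2-fold higher number from compound 2 to compound 4 (0.08 log units; within the scatter).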

Compound 4, half-maximal inhibitory concentration: 12900 nM
Compound 4: middle estimate off by 3.1-fold (0.49 log units), on the high side; measured number below the stated range.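

In this assay, among these compounds, hydrogen in place of methyl on an oxygen on an aromatic ring gives a 2.6-fold lower number from compound 2 to compound 4 (0.41 log units; beyond the scatter), the first step in this set that lies beyond the scatter. Among the compounds shown here, the earlier steps both rested on limits, and their floors lay within the scatter, so this is the first firm evidence that the group on this oxygen affects the number. The step is modest, but it shows that methoxy to hydroxy at this place is a change the assay can register as a gain.

On these data alone, whether an amine in place of the hydroxy, or a longer chain on the same oxygen, would shift the number further remains open, as does whether the hydroxy gives the same gain alongside the 4-fluorophenyl of compound 3. Comparison across the set stays narrow: the limit of > 50000 nM in this assay, at which 2 of the 4 values shown sit.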